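A few compounds are considered here, and "the series" means these few. Any claim that something is new, unique, unknown or untested is made for them only; others in the source may bear on it.

Measured in an ADME assay on CHO cells (Cricetulus griseus) for cytotoxicity, read by LDH release; a higher number here means a weaker inhibitor, a lower number a stronger inhibitor:
Compound 1 `CCCCC(NC(=O)C(C)Oc1ccc(Cl)cc1Cl)c1ccc(F)cc1`: > 100000 nM, a limit of the assay
Compound 2 `CC(Oc1ccc(Cl)cc1Cl)C(=O)NCc1cccc(F)c1`: 27000 nM
Compound 3 `CC(Oc1ccc(Cl)cc1Cl)C(=O)NCc1ccccc1F`: 47000 nM

Among the measured compounds shown here, compound 3 gives 47000 nM, and its only neighbour with a true number lies close: a 1.7-fold higher number from compound 2 to compound 3 (0.24 log units; within the scatter). Compound 4 `CC(Oc1ccc(Cl)cc1Cl)C(=O)NCc1cccc(Cl)c1` has not yet been measured. It carries 3-chlorophenyl in place of 2-fluorophenyl on a saturated chain carbon bound to an amide-type nitrogen. For the measured compounds named here, the one measured step that changes this phenyl group is a 1.7-fold higher number from compound 2 to compound 3 (0.24 log units; within the scatter), which offers a single small precedent. No step beyond the scatter is therefore expected in this assay. The expected change is a 1.6-fold lower number from compound 3 to compound 4 (0.19 log units; within the scatter). For compound 4 the estimate is 30000 nM, with an expected range from 12000 nM to 75000 nM.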

Compound 4, half-maximal inhibitory concentration: 19000 nM
Estimate against measurement, compound 4: 1.6-fold (0.20 log units) above, within the range that was stated.
By their numbers in this assay, from the lowest: compounds 4, 2 and 3 (each within the scatter of the next, the first and the last beyond it). At a limit, above all of these: compound 1.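

In this assay, among the compounds shown here, replacing 2-fluorophenyl with 3-chlorophenyl gives the only step among the measured compounds that lies beyond the scatter (a 2.5-fold lower number from compound 3 to compound 4 (0.39 log units; beyond the scatter)). Chloro in place of fluoro on an aromatic carbon stays within the scatter (a 1.4-fold lower number from compound 2 to compound 4 (0.15 log units; within the scatter)). At this place, therefore, 3-chlorophenyl and 3-fluorophenyl do not separate, and only 2-fluorophenyl and 3-chlorophenyl do.

On these data alone, whether an amine or a carboxylic acid on this phenyl group would move the number further remains open. Nothing measured here explains the difference between compound 3 and compound 4.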